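Chloro for methoxy on two related piperazine cores

The compounds below may be only part of what the source reports. "The series", "measured", "known", "first", "only" and "open" are said of these compounds alone.

Compound 1 `COc1ccc(N2CCN(CC(=O)N3CCN(c4nnc(-c5ccccc5)c(-c5ccccc5)n4)CC3)CC2)cc1`: in a functional assay on MCF7 cells (Homo sapiens) for cytotoxicity, read by MTT assay, with a stated time of 24 h (a higher number here means a weaker inhibitor, a lower number a stronger inhibitor), compound 1 gives only a limit, > 910000 nM.
Compound 2 `O=C(CN1CCN(c2ccc(Cl)cc2)CC1)N1CCN(c2nnc(-c3ccccc3)c(-c3ccccc3)n2)CC1`: in this assay compound 2 gives 56300 nM.
Compound 3 `COc1ccc(N2CCN(CC(=O)N3CCN(c4nnc(-c5ccc(Cl)cc5)c(-c5ccc(Cl)cc5)n4)CC3)CC2)cc1`: in this assay compound 3 gives only a limit, > 809000 nM.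

Compound 1 and compound 2 share a core and differ in one place, (chloro in place of methoxy on an aromatic carbon). That change gave an at least 16-fold lower number from compound 1 to compound 2 (1.20 log units; beyond the scatter), a step that starts from a limit and so is known only as a least bound. Compound 3 carries the same change-ready methoxy group on a different core; how the core of compound 3 differs from that of compound 1 is not broken down here. Compound 4 `O=C(CN1CCN(c2ccc(Cl)cc2)CC1)N1CCN(c2nnc(-c3ccc(Cl)cc3)c(-c3ccc(Cl)cc3)n2)CC1` stands to compound 3 exactly as compound 2 stands to compound 1: chloro in place of methoxy on an aromatic carbon, at the same place in both pairs, so this is the same change. Among the measured compounds shown here, for compound 4 a step of similar size is expected, an at least 13-fold lower number from compound 3 to compound 4 (1.12 log units; beyond the scatter), resting on the one measured instance of this change, an at least 16-fold lower number from compound 1 to compound 2 (1.20 log units; beyond the scatter), and on the limit of compound 3 at the limit of > 809000 nM in this assay, at which 1 of the 3 values shown sits. On that basis compound 4 is estimated at 60000 nM in this assay, between 15000 nM and 400000 nM.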

Compound 4, half-maximal inhibitory concentration: > 803000 nM
Compound 4 gave a limit, no number; the forecaster's own chance of this, stated with the estimate: 25%; at least 13-fold (1.12 log units) between middle value and limit.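

In this assay compound 3 gives only a limit, > 809000 nM. Among the compounds shown here, compound 4 also gives only a limit, > 803000 nM, so no step between the two can be read. The compounds shown leave open whether chloro in place of methoxy lowers the number on the core of compound 3, as it did on the core of compound 1.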